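The source may hold more compounds than are shown below. What is called first, only, known or untested is meant among the compounds shown, and "the series" means these compounds.

In a functional assay on MT4 cells (Homo sapiens) for cytotoxicity (on this read-out lower numbers stand for higher toxicity in this test and higher numbers for lower toxicity in this test), the measured compounds read as follows:
- Compound 1 `Cc1c(Cc2c(F)cccc2F)nc(SC(C)C)[nH]c1=O` gives > 200000 nM, a limit
- Compound 2 `CCC(C)Sc1nc(O)cc(C(C)c2ccccc2)n1` gives 200000 nM, a number
- Compound 3 `CCC(C)Sc1nc(O)cc(C(CC)c2ccccc2)n1` gives > 200000 nM, a limit

Compound 3 therefore stands only at a limit, with no number of its own. Compound 4 `CCC(c1ccccc1)c1cc(O)nc(SC2CCCCC2)n1` differs from it by cyclohexyl in place of sec-butyl on a sulfur. Within the data shown here, the only measured step, a number no lower from compound 2 to compound 3 (the limit leaves the size open), falls on a saturated chain carbon and not on the sulfur, and its size stays open. For compound 3, with its limit of > 200000 nM, no step beyond the scatter is expected in this assay because of the limit of > 200000 nM in this assay, at which 2 of the 3 values shown sit. The expected step is an at least 1.3-fold lower number from compound 3 to compound 4 (0.12 log units; that floor lies within the scatter). For compound 4 the estimate is 150000 nM, with an expected range from 50000 nM to 300000 nM.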

Compound 4, half-maximal cytotoxic concentration: 51000 nM
The estimate for compound 4 lay 2.9-fold (0.47 log units) above the measured number; the measured number falls inside the stated range.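

On the sulfur, in this assay, cyclohexyl in place of sec-butyl gives an at least 3.9-fold lower number from compound 3 to compound 4 (0.59 log units; beyond the scatter). This is the first step shown to lie beyond the scatter, and it places a change in this read-out at the sulfur, whereas a number no lower from compound 2 to compound 3 (the limit leaves the size open) fell on a saturated chain carbon. Its full size stays open since compound 3 stands only at a limit: the limit of > 200000 nM in this assay, at which 2 of the 4 values shown sit.

The compounds shown do not separate the effect of the ring from that of the added carbons. As far as these compounds go, how a longer open chain such as n-hexyl, or a phenyl group, would read on the sulfur also remains open.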